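This account rests on a few compounds, and the source may have more. Where it says the series, first, only, none or still open, it means among the compounds named here.

Measured so far in a functional assay on MDA-MB-231 cells (Homo sapiens) for antiproliferative activity, read by MTT assay, with a stated time of 24 h; on this read-out lower numbers stand for stronger inhibition and higher numbers for weaker inhibition:
compound 1 `N#Cc1ccc(S(=O)(=O)NC(CC(=O)O)c2ccccc2)cc1` gives 48700 nM
compound 2 `O=C(O)CC(NS(=O)(=O)c1ccc(C(F)(F)F)cc1)c1ccccc1` gives 56100 nM
compound 3 `O=C(O)CC(NS(=O)(=O)c1ccc(C(F)(F)F)cc1)c1ccc(Cl)cc1Cl` gives 30400 nM

All three share one core and differ in only two places. Compound 3 differs from compound 2 by 2,4-dichlorophenyl in place of phenyl on a saturated chain carbon bound to a saturated chain carbon and a sulfonamide nitrogen, and the step is a 1.8-fold lower number from compound 2 to compound 3 (0.27 log units; within the scatter). Compound 1 differs from compound 2 by cyano in place of trifluoromethyl on an aromatic carbon, and the step is a 1.2-fold lower number from compound 2 to compound 1 (0.06 log units; within the scatter). Neither change moves the number beyond the scatter, so the three values cannot be ranked against each other.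

Compound 4 `N#Cc1ccc(S(=O)(=O)NC(CC(=O)O)c2ccc(Cl)cc2Cl)cc1` has not been measured. It differs from compound 3 by cyano in place of trifluoromethyl on an aromatic carbon. For the measured compounds named here, this is the same change that was made from compound 2 to compound 1, at the same place, so the step already seen is the only guide. Compound 4 is expected to lie a 1.2-fold lower number from compound 3 to compound 4 (0.08 log units; within the scatter) from compound 3, because the earlier step of a 1.2-fold lower number from compound 2 to compound 1 (0.06 log units; within the scatter) stayed within the scatter. The estimate for compound 4 in this assay is 25000 nM, most likely between 12000 nM and 55000 nM.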

Compound 4, half-maximal inhibitory concentration: 12600 nM
Estimate against measurement, compound 4: 2.0-fold (0.30 log units) above; the range from low to high includes it.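

In this assay, cyano in place of trifluoromethyl gives a 2.4-fold lower number from compound 3 to compound 4 (0.38 log units; beyond the scatter), a step beyond the scatter, whereas the same change on the other core stayed within it, yet the two steps cannot be told apart: the same change on two cores in this assay, a 1.2-fold lower number (0.06 log units; within the scatter) from compound 2 to compound 1 and a 2.4-fold lower number (0.38 log units; beyond the scatter) from compound 3 to compound 4, 2.1-fold (0.32 log units) apart, within the scatter of two such steps

Likewise, 2,4-dichlorophenyl in place of phenyl gives a 3.9-fold lower number from compound 1 to compound 4 (0.59 log units; beyond the scatter), and this step also cannot be told apart from its earlier counterpart: the same change on two cores in this assay, a 1.8-fold lower number (0.27 log units; within the scatter) from compound 2 to compound 3 and a 3.9-fold lower number (0.59 log units; beyond the scatter) from compound 1 to compound 4, 2.1-fold (0.32 log units) apart, within the scatter of two such steps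

So these four compounds give no sign that either change behaves differently on the two cores, but they do not prove that the steps are equal, and one pair of cores says nothing about any other core in the series.

The compounds shown leave open how a nitro or methoxy group would compare with cyano and trifluoromethyl in that place. They also leave open whether either step would carry over to a compound with a methyl ester or an amide in place of the carboxylic acid.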